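Oxyacetamide series: pyridinyl amide replacing methoxyphenyl amide

The source may hold more compounds than are shown below. What is called first, only, known or untested is meant among the compounds shown, and "the series" means these compounds.

Two compounds of this series carry values in a physicochemical assay for lipophilicity, read by HPLC, in phosphate buffer, measured as chromatographic lipophilicity, at pH 7.4 (on this read-out higher numbers stand for higher lipophilicity and lower numbers for lower lipophilicity), so far. Compound 1 `COc1ccc2nc(C)cc(NC(=O)C(=O)Nc3cc(C)cc(C)c3)c2c1` is an oxalamide bearing a dimethylphenyl group; in this assay compound 1 gives 6.47. Compound 2 `COc1cccc(NC(=O)COc2cc(C)nc3ccc(OC)cc23)c1` carries the shared core through an ether-linked acetamide to a 3-methoxyphenyl group; in this assay compound 2 gives 4.49. Among the measured compounds shown here, on the two numbers known, compound 2 stands lowest, with compound 1 the nearer and only neighbour, lying above it by a gap that is beyond the scatter. For the measured compounds named here, compounds 1 and 2 differ in more than one place, so no single step between them is counted.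

Compound 3 `COc1ccc2nc(C)cc(OCC(=O)Nc3cccnc3)c2c1` is not yet measured in this assay. It differs from compound 2 as follows: pyridin-3-yl in place of 3-methoxyphenyl on an amide-type nitrogen. Going by the values given here, no measured pair shows this change on its own, so its size must be estimated. A downward step is expected, of a size clearly beyond the scatter: the step from compound 2 to compound 3 is estimated at a number 1.29 log units lower from compound 2 to compound 3 (beyond the scatter). For compound 3 in this assay a value of 3.2 is expected, within a range of 2.6 to 3.8.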

Compound 3, distribution coefficient: 2.46
Beside the measured number, compound 3's estimate is 0.74 log units above it, outside the stated range (below it).
By their numbers in this assay, from the lowest: compound 3; then compound 2; then compound 1.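

In this assay, among the compounds shown here, pyridin-3-yl in place of 3-methoxyphenyl on an amide-type nitrogen gives a number 2.03 log units lower from compound 2 to compound 3 (beyond the scatter), the first step that can be read for a change in one place. It shows that the read-out at this position, on an amide-type nitrogen whose other neighbour is the carbonyl carbon, responds strongly to the exchange of one six-membered aromatic ring for another, even though the counts of hydrogen-bond donors and acceptors stay the same and the heavy-atom count goes only from 8 to 6. No supporting measurement bears on what lies behind the size of this step.

The compounds shown leave open how much of the step goes with the loss of the methoxy group and how much with the ring nitrogen of pyridin-3-yl, a split that a plain phenyl group on the same amide-type nitrogen would address. Also open, going by these compounds, is whether pyridin-2-yl or pyridin-4-yl at this place would give a step of similar size, and whether the same exchange would carry over to the oxalamide of compound 1.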